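The source may hold more compounds than are shown below. What is called first, only, known or untested is meant among the compounds shown, and "the series" means these compounds.

In a functional assay with Homo sapiens as the target (on this read-out lower numbers stand for stronger inhibition and higher numbers for weaker inhibition), the measured compounds give:
compound 1 `CC(C)[C@H](NC(=O)COc1cccc2ccccc12)C(=O)N[C@@H](CC(=O)O)C(=O)COc1cccc2ccccc12`: 19000 nM
compound 2 `CC(C)[C@H](NC(=O)COc1cccc2ccccc12)C(=O)N[C@@H](CC(=O)O)C(=O)COc1ccc(-c2ccccc2)cc1`: 38700 nM
compound 3 `CC(C)[C@H](NC(=O)COc1cccc2ccccc12)C(=O)N[C@@H](CC(=O)O)C(=O)COc1cc(F)cc(F)c1`: 15900 nM

Compound 2 gives the highest number of the three in this assay; compound 1 sits a 2.0-fold higher number from compound 1 to compound 2 (0.31 log units; beyond the scatter) away and compound 3 furthest, at a 2.4-fold lower number from compound 2 to compound 3 (0.39 log units; beyond the scatter). Compound 4 `CC(C)[C@H](NC(=O)COc1cccc2ccccc12)C(=O)N[C@@H](CC(=O)O)C(=O)COc1c(F)cc(F)cc1F` is not yet measured. Its difference from compound 2 is 2,4,6-trifluorophenyl in place of 4-phenylphenyl on an oxygen on a saturated carbon. The step that bears most directly on it is the exchange of 4-phenylphenyl for 3,5-difluorophenyl, a 2.4-fold lower number from compound 2 to compound 3 (0.39 log units; beyond the scatter); the related exchange from naphthalen-1-yl, a 1.2-fold lower number from compound 1 to compound 3 (0.08 log units; within the scatter), stayed within the scatter. A lower number of modest size is therefore expected in this assay, roughly matching compound 3. For compound 4 the estimate is 17000 nM with a range of 8000 nM to 36000 nM, meaning an expected step of a 2.3-fold lower number from compound 2 to compound 4 (0.36 log units; beyond the scatter).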

Compound 4, half-maximal inhibitory concentration: 14900 nM
Compound 4: middle estimate off by 1.1-fold (0.06 log units), on the high side; the measured number falls inside the stated range.
By their numbers in this assay, from the lowest: compounds 4, 3 and 1 (each within the scatter of the next); then compound 2.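

On the oxygen on a saturated carbon, 2,4,6-trifluorophenyl in place of 4-phenylphenyl again gives a modest drop in the number (a 2.6-fold lower number from compound 2 to compound 4 (0.41 log units; beyond the scatter)), so this drop in this assay does not depend on one fluorine pattern. Compound 4 does not separate from the other two compounds, either with the added fluorine pattern (a 1.1-fold lower number from compound 3 to compound 4 (0.03 log units; within the scatter)) or against naphthalen-1-yl (a 1.3-fold lower number from compound 1 to compound 4 (0.11 log units; within the scatter)), which leaves compound 2 alone apart from a level group. No measurement on hand accounts for these differences. As far as these compounds go, whether an amine or a carboxylic acid on the phenyl ring would move the number beyond this level stays open. The same holds for a longer chain on the oxygen.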